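Swapping the indolyl ketone for a dimethoxyphenyl ketone

The source may hold more compounds than are shown below. What is called first, only, known or untested is meant among the compounds shown, and "the series" means these compounds.

Three related enones have been measured in a functional assay on MCF7 cells (Homo sapiens) for inhibition, read by sulforhodamine B assay, with a stated time of 72 h; a lower number here means a stronger inhibitor, a higher number a weaker inhibitor. Compound 1 `COc1ccc(C(=O)/C=C/c2cn(-c3ccccc3)nc2-c2ccsc2)c(OC)c1OC` gives 7400 nM, compound 2 `O=C(/C=C/c1cn(-c2ccccc2)nc1-c1cccnc1)c1cc[nH]c1` gives 6900 nM, and compound 3 `O=C(/C=C/c1cn(-c2ccccc2)nc1-c1cccnc1)c1c[nH]c2ccccc12` gives 2600 nM. Compound 3 therefore stands lowest of the three, with its steps to both compound 2 and compound 1 beyond the scatter. The one single-site step among these is a 2.7-fold lower number from compound 2 to compound 3 (0.42 log units; beyond the scatter), which shows that enlarging the five-membered heteroaryl on the carbonyl carbon to a fused bicyclic one lowered the number by a modest amount.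

Compound 4 `COc1ccc(C(=O)/C=C/c2cn(-c3ccccc3)nc2-c2cccnc2)cc1OC` keeps the shared core of compound 3 and changes only the group on the carbonyl carbon: 3,4-dimethoxyphenyl in place of 1H-indol-3-yl on a carbonyl carbon. Among the compounds with values here, no measured pair covers this exact exchange. The only bearing comes from the measured step from compound 2 to compound 3, which suggests that the indolyl ketone is the favourable one among the measured variants, and from compound 1, whose methoxyphenyl ketone on a differently substituted core sits well above compound 3. Undoing the indolyl group is thus expected to raise the number, and the estimated step is a 2.3-fold higher number from compound 3 to compound 4 (0.36 log units; beyond the scatter). Compound 4 is expected to give about 6000 nM, within a range from 2500 nM to 15000 nM.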

Compound 4, half-maximal inhibitory concentration: 1700 nM
Compound 4: middle estimate off by 3.5-fold (0.55 log units), on the high side; measured number below the stated range.
By their numbers in this assay, from the lowest: compounds 4 and 3 (each within the scatter of the next); then compounds 2 and 1 (each within the scatter of the next).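

At this carbonyl carbon, 3,4-dimethoxyphenyl in place of 1H-indol-3-yl gives a 1.5-fold lower number from compound 3 to compound 4 (0.18 log units; within the scatter) in this assay, so the fused bicyclic group shows no measurable advantage over a single benzene ring, and the hydrogen-bond donor counted on 1H-indol-3-yl can go without a step beyond the scatter. The same group in place of 1H-pyrrol-3-yl gives a 4.1-fold lower number from compound 2 to compound 4 (0.61 log units; beyond the scatter) and thus, among the three groups compared on this core, 1H-pyrrol-3-yl is the one set apart, while 1H-indol-3-yl and 3,4-dimethoxyphenyl cannot be told apart. Nothing given here accounts for these results at this position.

The compounds shown leave open whether both methoxy groups are needed, and how a plain phenyl, a hydroxyphenyl, an aminophenyl or a phenyl bearing a carboxylic acid would fare on the same carbonyl carbon. They also leave open what the trimethoxyphenyl ketone of compound 1 would give on the shared core of compound 4, since compound 1 differs from it in more than one place.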